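The compounds below may be only part of what the source reports. "The series", "measured", "known", "first", "only" and "open" are said of these compounds alone.

Values in a functional assay on Hep 3B2 cells (Homo sapiens) for antiproliferative activity, read by sulforhodamine B assay, with a stated time of 48 h; a higher number here means a weaker inhibitor of growth, a lower number a stronger inhibitor of growth:
- compound 1 `CC(C)CCc1c(OCCCCCCCC(=O)NO)ccc(CCC(=O)NO)c1O`: 1270 nM
- compound 2 `CC(C)CCc1c(OCCCCC(=O)NO)ccc2ccc(=O)oc12`: 1310 nM
- compound 3 `CC(C)CCc1c(OCCCCCC(=O)NO)ccc2c1OC(=O)CC2`: > 30000 nM

For the measured compounds named here, compound 1 at 1270 nM and compound 2 at 1310 nM lie within the scatter of each other, and these are the only two numbers. Compound 3 gives > 30000 nM, which is a limit of the assay and not a number.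

Compound 4 `CC(C)CCc1c(OCCCCCC(=O)NO)ccc(CCC(=O)NO)c1O` comes from compound 1 by one change, (hydroxycarbamoyl in place of 2-(hydroxycarbamoyl)ethyl on a saturated chain carbon, five bonds along the chain from an oxygen on an aromatic ring). Cut one bond further out, the same difference reads 5-(hydroxycarbamoyl)pentyl to 3-(hydroxycarbamoyl)propyl. The rest of the structure of compound 1 stays as it is.

Going by the values given here, no measured step speaks directly to this change, so the expectation is anchored on compound 1 at 1270 nM. In this assay a small step towards weaker growth inhibition is expected, with no change beyond the scatter also possible. A fall to the limit seen for compound 3 is not expected, though it cannot be excluded.

The estimated move is a 1.7-fold higher number from compound 1 to compound 4 (0.24 log units; within the scatter). For compound 4 the expected value is 2200 nM, with an estimated range of 700 nM to 7000 nM.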

Compound 4, concentration for 50% growth inhibition: 1980 nM
Beside the measured number, compound 4's estimate is 1.1-fold (0.05 log units) above it; the range from low to high includes it.
By their numbers in this assay, from the lowest: compounds 1, 2 and 4 (each within the scatter of the next). At a limit, above all of these: compound 3.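

In this assay, placing hydroxycarbamoyl in place of 2-(hydroxycarbamoyl)ethyl on a saturated chain carbon, five bonds along the chain from an oxygen on an aromatic ring, gives a 1.6-fold higher number from compound 1 to compound 4 (0.19 log units; within the scatter). For the compounds shown here, this is the only measured step, and it shows that going from 5-(hydroxycarbamoyl)pentyl to 3-(hydroxycarbamoyl)propyl at this position, with the rest of compound 1 unchanged, brings no change beyond the scatter in this read-out. The value of compound 3 is a limit and not a number, and it remains the only such value in the series: the limit of > 30000 nM in this assay, at which 1 of the 4 values shown sits.

On these data alone, whether the same holds for a shorter chain, such as (hydroxycarbamoyl)methyl, or for a longer chain than 5-(hydroxycarbamoyl)pentyl remains open, so no trend with chain length can be drawn from a single step. Also open, as far as these compounds go, is whether a carboxylic acid or a primary amide in place of the hydroxycarbamoyl group at the end of this chain would stay within the scatter of compound 1.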